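A few compounds are considered here, and "the series" means these few. Any claim that something is new, unique, unknown or untested is made for them only; others in the source may bear on it.

Of the compounds shown here, three sharing one core have been measured in an ADME assay on L02 cells (Homo sapiens) for cytotoxicity, read by MTT assay, with a stated time of 24 h; a higher number here means a weaker inhibitor, a lower number a stronger inhibitor. Compound 1 `CN1C/C(=C\c2cccnc2)C(=O)/C(=C/c2ccccc2F)C1`, with methyl on the amine nitrogen in the ring, gives 15900 nM. Compound 2 `O=C1/C(=C/c2cccnc2)CN(S(=O)(=O)c2ccccc2)C/C1=C\c1ccccc1F`, with phenylsulfonyl there, gives 15300 nM. Compound 3 `Cc1ccc(S(=O)(=O)N2C/C(=C\c3cccnc3)C(=O)/C(=C/c3ccccc3F)C2)cc1`, with (4-methylphenyl)sulfonyl there, gives 14900 nM, which places it level with the other two within the scatter.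

Compound 4 `O=C1/C(=C/c2cccnc2)CN(S(=O)(=O)c2ccc(C(F)(F)F)cc2)C/C1=C\c1ccccc1F` has trifluoromethyl in place of methyl on an aromatic carbon.

Going by the values given here, the closest precedent is a 1.0-fold lower number from compound 2 to compound 3 (0.01 log units; within the scatter), which changes the same aromatic carbon and stays within the scatter. The larger swaps on the nitrogen, a 1.0-fold lower number from compound 1 to compound 2 (0.02 log units; within the scatter) and a 1.1-fold lower number from compound 1 to compound 3 (0.03 log units; within the scatter), stay within it too. Among the compounds with values here, no measured compound yet carries trifluoromethyl, so this evidence is indirect. Even so, no step beyond the scatter is expected in this assay, and no direction is favoured. The step expected is a 1.0-fold lower number from compound 3 to compound 4 (0.01 log units; within the scatter). For compound 4 the estimated value is 14500 nM, with an expected range of 9000 nM to 22000 nM.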

Compound 4, half-maximal inhibitory concentration: 11300 nM
Compound 4: the middle estimate sits 1.3-fold (0.11 log units) above what was measured; the measured number falls inside the stated range.
By their numbers in this assay, from the lowest: compounds 4, 3, 2 and 1 (each within the scatter of the next).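

Trifluoromethyl, with four heavy atoms where methyl has one, is the first group on this aromatic carbon to carry fluorine, and in this assay it gives a 1.3-fold lower number from compound 3 to compound 4 (0.12 log units; within the scatter) and, measured against hydrogen at the same place, a 1.4-fold lower number from compound 2 to compound 4 (0.13 log units; within the scatter). Both steps lie within the scatter, so hydrogen, methyl and trifluoromethyl on this carbon cannot be told apart by these numbers. The earlier compounds shown here showed this only for the smaller methyl change, so the flat picture at this position now also covers a larger group with a different atom make-up.

As far as these compounds go, it remains open whether an amine or a carboxylic acid on this same aromatic carbon, or a longer chain on the amine nitrogen in the ring, would give a step beyond the scatter. No evidence on why these numbers stay so close is available.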